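The source may report more compounds than this note shows. Statements on the series, on what has been measured and on what is new or still open speak of the compounds shown alone.

Measured in an ADME assay on microsomes from liver (Mus musculus) for metabolic stability, with a stated time of 10 min; a lower number here means that less of the compound is left, a higher number that more of the compound is left:
Compound 1 `O=C(O)C1CCN(C(=O)N2CC[C@](c3ccc(C(F)(C(F)(F)F)C(F)(F)F)cc3)(S(=O)(=O)c3ccc(F)cc3)C2)CC1`: 88%
Compound 2 `Cc1ccc(S(=O)(=O)[C@@]2(c3ccc(C(F)(C(F)(F)F)C(F)(F)F)cc3)CCN(C(=O)[C@H]3CC[C@H](C(=O)O)CC3)C2)cc1`: 85%

Compound 2, at 85%, lies within the scatter of compound 1, at 88%, so the two cannot be told apart in this assay. Compound 3 `COc1ccc(S(=O)(=O)[C@@]2(c3ccc(C(F)(C(F)(F)F)C(F)(F)F)cc3)CCN(C(=O)[C@H]3CC[C@H](C(=O)O)CC3)C2)cc1` follows from compound 2 with methoxy in place of methyl on an aromatic carbon, para to a large group: methoxy in place of methyl on an aromatic carbon. For the measured compounds named here, no measured pair shows this change, so any forecast is uncertain. A small fall is expected, possibly no larger than the scatter, and the estimated step is a number 6 percentage points lower from compound 2 to compound 3 (within the scatter). Compound 3 is expected to give 79%, within an estimated range of 62% to 92%.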

Compound 3, percent of the compound remaining: 98%
Compound 3: the middle estimate sits 19 percentage points below what was measured; the measured number lies above the stated range.
By their numbers in this assay, from the lowest: compounds 2, 1 and 3 (each within the scatter of the next, the first and the last beyond it).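

In this assay the change from methyl to methoxy on an aromatic carbon, para to a large group, gives a number 13 percentage points higher from compound 2 to compound 3 (beyond the scatter) and so separates two compounds by more than repeat measurements would. This place therefore responds to what it carries, and here the swap of (4-methylphenyl)sulfonyl for (4-methoxyphenyl)sulfonyl goes with more compound left, not less. Nothing shown here offers an explanation for this step. From the compounds shown here alone, it remains open whether an ethoxy group or an amine at this place would follow methoxy, and whether the same swap would give a similar step on the core of compound 1.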